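A few compounds are considered here, and "the series" means these few. Any claim that something is new, unique, unknown or untested is made for them only; others in the source may bear on it.

In an ADME assay on J774 cells (Mus musculus) for cytotoxicity (on this read-out lower numbers stand for an effect already at smaller amounts and higher numbers for an effect only at larger amounts of compound), compound 1 `CCCCc1cc2c(=O)c(CC)c[nH]c2cc1OCCOc1ccccc1` gives 360 nM, and compound 3 `COC(=O)c1c[nH]c2cc(OCc3ccccc3)ccc2c1=O` gives 18900 nM. Compound 2 `CCCCc1ccc2[nH]cc(C(=O)OC)c(=O)c2c1` gives > 20000 nM, which is a limit of the assay and not a number. Compound 2 therefore has no exact position among the measured compounds: it rests at the limit of > 20000 nM in this assay, at which 1 of the 3 values shown sits.

Compound 4 `CCc1ccc2[nH]cc(C(=O)OC)c(=O)c2c1` differs from compound 2 in one place: hydrogen in place of ethyl on a saturated chain carbon, two bonds along the chain from an aromatic carbon. In words, hydrogen stands in place of ethyl on a saturated chain carbon, two bonds along the chain from an aromatic carbon, so the butyl chain becomes an ethyl chain. For the measured compounds named here, no measured pair shows what this kind of change does in this assay, so any forecast is rough.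

The expected change, a step that the limit leaves unreadable from compound 2 to compound 4, is none beyond the usual scatter, and this rests on the limit reading of compound 2 at > 20000 nM. For compound 4 the estimated value is 25000 nM, with an expected range from 12000 nM to 50000 nM.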

Compound 4, half-maximal effective concentration: > 20000 nM
Compound 4: only a limit was reported; the forecaster's own chance of this, stated with the estimate: 75%; the middle value is on the limit's open side.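

For the compounds shown here, compound 2 and compound 4 each gave only a limit of the assay and not a number, so no step from one to the other can be read: the limit of > 20000 nM in this assay, at which 2 of the 4 values shown sit. The compounds shown leave open whether going from a butyl chain to an ethyl chain changes anything in this assay at all.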